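Pentyl in Place of Phenyl: An Expected Partial Agonist

The compounds below may be only part of what the source reports. "The series", "measured", "known", "first", "only" and "open" are said of these compounds alone.

Compound 1 `N/C(=N\C(=O)NCc1ccccc1)NC1CCc2nc(N)sc2C1` was examined in a functional assay on membranes from Sf9 cells for agonist activity at histamine H2 receptor (Homo sapiens), read by scintillation counting and GTPgammaS binding, with a stated time of 90 min (a higher number here means a larger maximal response, a lower number a smaller maximal response), where compound 1 gives 0.53. Among the compounds with values here, of the two numbers known, this is the lowest; the nearest is compound 2 `Cc1ccc(CC(C)CNC(=O)/N=C(\N)NCCCc2sc(N)nc2C)cc1`, which in this assay gives 0.68, a gap beyond the usual scatter. Compound 3 `CCCCCCNC(=O)/N=C(\N)NC1CCc2nc(N)sc2C1` has not yet been measured. It differs from compound 1 in one place: pentyl in place of phenyl on a saturated chain carbon bound to an amide-type nitrogen. Within the data shown here, no step between two measured compounds covers a change of this kind, so nothing measured speaks directly to its size. The step a number 0.020 higher from compound 1 to compound 3 (within the scatter) is expected to be small and of uncertain direction, quite possibly within the scatter. In this assay compound 3 is therefore estimated to give 0.55, within a range from 0.35 to 0.75.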

Compound 3, intrinsic activity: the largest response reached, as a fraction of the reference agonist's: 0.16
For compound 3 the middle estimate is 0.39 above the measured one; measured number outside the range, below it.
By their numbers in this assay, from the lowest: compound 3; then compound 1; then compound 2.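

In this assay, within the data shown here, the exchange of phenyl for pentyl on a saturated chain carbon bound to an amide-type nitrogen gives the step (a number 0.37 lower from compound 1 to compound 3 (beyond the scatter)), the first measure of change at this position. It shows that, on the core of compound 1, the maximal response depends strongly on which of these two groups is present, even though neither carries hydrogen-bond donors, hydrogen-bond acceptors or a net charge. Nothing at hand accounts for the size of this step.

This single pair cannot separate the loss of the aromatic ring from the introduction of an open chain, and a cyclohexyl group at this place would bear on that question. As far as these compounds go, how a shorter propyl chain, a longer octyl chain or an added amine at the chain end would compare remains open.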